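The source may report more compounds than this note shows. Statements on the series, on what has been measured and on what is new or still open speak of the compounds shown alone.

Measured so far in a functional assay on the whole organism (stomach) for inhibition, with Canis familiaris (Canis lupus familiaris) as the target, at a dose of 5 mg/kg by the intravenous route; on this read-out higher numbers stand for a stronger effect at the one dose given and lower numbers for a weaker effect:
- compound 1, `Cc1nc2c(OCc3ccccc3)cccn2c1C#N`: 4%
- compound 2, `Cc1nc2c(OCc3ccccc3)cccn2c1CCC#N`: 20%

Going by the values given here, compound 2 stands highest of the two numbers in this assay; its nearest neighbour is compound 1, and the one measured step, a number 16 percentage points higher from compound 1 to compound 2 (beyond the scatter), lies beyond the scatter and is of modest size. That step is the only one recorded, and it concerns the length of the chain carrying the nitrile on the shared core.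

Compound 3, `Cc1nc2c(OCc3ccccc3)cccn2c1CO`, is not yet measured. It differs from compound 2 in one place:

hydroxy in place of cyanomethyl on a saturated chain carbon bound to an aromatic carbon

The step from compound 1 to compound 2 bears on this change only in part: it shows that lengthening the chain on that position raised inhibition, whereas compound 3 shortens the chain again and exchanges the nitrile for a hydroxy. Among the compounds with values here, no measured step covers the hydroxy itself. With compound 2 as the starting point and compound 1 marking the shorter-chain end, a drop back toward the lower number is expected for compound 3, so the step is estimated as a number 10 percentage points lower from compound 2 to compound 3 (within the scatter) in this assay. For compound 3 the expected value in this assay is 10%, with a range from 0% to 28%.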

Compound 3, a percentage reported as inhibition, in the whole organism at one dose (the size of the read-out at that dose, not a potency): 80%
For compound 3 the middle estimate is 70 percentage points below the measured one; the measured number lies above the stated range.
By their numbers in this assay, from the lowest: compound 1; then compound 2; then compound 3.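

In this assay, the exchange of cyanomethyl for hydroxy on a saturated chain carbon bound to an aromatic carbon gives a number 60 percentage points higher from compound 2 to compound 3 (beyond the scatter), and hydroxymethyl in place of cyano on an aromatic carbon gives a number 76 percentage points higher from compound 1 to compound 3 (beyond the scatter). Chain length alone therefore does not order the series: a number 16 percentage points higher from compound 1 to compound 2 (beyond the scatter) first suggested that a longer chain raises the number, but compound 3 goes against that pattern, carrying hydroxymethyl rather than 2-cyanoethyl and reaching the highest number of the three. No measurement on hand accounts for the size of these steps.

Still open, going by these compounds, is whether the hydroxymethyl group itself is needed, or whether methoxymethyl, aminomethyl, a carboxylic acid or a longer chain such as 2-hydroxyethyl would give a comparable number on the shared core. Since this assay reports the effect at one dose, the compounds shown also leave open whether their effects would stand in the same order at any other dose.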